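This account rests on a few compounds, and the source may have more. Where it says the series, first, only, none or still open, it means among the compounds named here.

Measured compounds in this series:
compound 1 `CC(C)=CCC/C(C)=C/CC/C(C)=C/CC[C@@H]1[C@@]2(C)CC/C(=N\OCc3cn(-c4ccccc4C#N)nn3)C(C)(C)[C@@H]2CC[C@@]1(C)O` gives 24900 nM
compound 2 `CC(C)=CCC/C(C)=C/CC/C(C)=C/CC[C@@H]1[C@@]2(C)CC/C(=N\OCc3cn(-c4cccc([N+](=O)[O-])c4)nn3)C(C)(C)[C@@H]2CC[C@@]1(C)O` gives 20700 nM
compound 3 `CC(C)=CCC/C(C)=C/CC/C(C)=C/CC[C@@H]1[C@@]2(C)C/C(=C\c3ccc(OCc4cn(-c5ccccc5C#N)nn4)cc3)C(=O)C(C)(C)[C@@H]2CC[C@@]1(C)O` gives 29900 nM

All three numbers come from a functional assay on MCF7 cells (Homo sapiens) for cytotoxicity, read by MTT assay, with a stated time of 48 h; on this read-out lower numbers stand for stronger inhibition and higher numbers for weaker inhibition. Compound 1 and compound 2 share one core and differ by 3-nitrophenyl in place of 2-cyanophenyl on an aromatic nitrogen; this gave a 1.2-fold lower number from compound 1 to compound 2 (0.08 log units; within the scatter). Compound 3 carries the same 2-cyanophenyl group on a different core; the difference between the two cores is not broken down here. The values of compound 3, compound 1 and compound 2 all lie within the scatter of one another.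

Compound 4 `CC(C)=CCC/C(C)=C/CC/C(C)=C/CC[C@@H]1[C@@]2(C)C/C(=C\c3ccc(OCc4cn(-c5cccc([N+](=O)[O-])c5)nn4)cc3)C(=O)C(C)(C)[C@@H]2CC[C@@]1(C)O` is not yet measured. It differs from compound 3 by 3-nitrophenyl in place of 2-cyanophenyl on an aromatic nitrogen, the same change, at the same place, as made from compound 1 to compound 2. Compound 4 is expected to show a step of a 1.2-fold lower number from compound 3 to compound 4 (0.08 log units; within the scatter) in this assay. Within the data shown here, this rests on a 1.2-fold lower number from compound 1 to compound 2 (0.08 log units; within the scatter), the only earlier instance of the change. In this assay compound 4 is estimated at 25000 nM, with a range of 12000 nM to 52000 nM.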

Compound 4, half-maximal inhibitory concentration: 79400 nM
Estimate against measurement, compound 4: 3.2-fold (0.50 log units) below; the measured number lies above the stated range.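

In this assay, placing 3-nitrophenyl in place of 2-cyanophenyl on the core of compound 3 gives a 2.7-fold higher number from compound 3 to compound 4 (0.42 log units; beyond the scatter), so the change does not carry over with the same effect between the two cores: the same change on two cores in this assay, a 1.2-fold lower number (0.08 log units; within the scatter) from compound 1 to compound 2 and a 2.7-fold higher number (0.42 log units; beyond the scatter) from compound 3 to compound 4, 3.2-fold (0.50 log units) apart, beyond the scatter of two such steps

The step seen on one core is therefore a poor guide to the step on the other within these two pairs. This does not show which structural difference between the cores is responsible, and one pair per core gives no general rule for the series.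

Open, from the compounds shown here alone, is whether an unsubstituted phenyl or an aminophenyl on that aromatic nitrogen would also behave differently on the two cores. Also open, going by these compounds, is whether the gap between the two steps appears in any other assay.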